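Lengthening the Diamine Chain: What Compound 4 Might Give

A few compounds are considered here, and "the series" means these few. Any claim that something is new, unique, unknown or untested is made for them only; others in the source may bear on it.

Of the compounds shown here, three have been measured in a physicochemical assay, read by spectrophotometry, with a stated time of 10 min, tested at 0.1 mM, in the presence of a further agent that is not named here; a higher number here means a stronger effect of the compound at the concentration tested, a lower number a weaker effect. Compound 1 `NCC(N)CC(=O)N1CCN(C(=O)CCn2cccc(O)c2=O)CC1` gives 30.7% in this assay. Compound 2 `NCC(N)CCC(=O)N1CCN(C(=O)CCn2cccc(O)c2=O)CC1` gives 36%. Compound 3 `NCC(N)CCCNC(=O)CCn1cccc(O)c1=O` gives 40.8%, the highest of the three numbers, though compound 2 sits within the scatter of it and only compound 1 lies beyond it.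

Compound 2 differs from compound 1 by 2,3-diaminopropyl in place of 1,2-diaminoethyl on a saturated chain carbon bound to a carbonyl carbon. That change gave a number 5.3 percentage points higher from compound 1 to compound 2 (within the scatter), so a single such lengthening of the diamine chain has so far not moved the read-out beyond the scatter.

Compound 4 `NCC(N)CCCCNC(=O)CCn1cccc(O)c1=O` has not yet been measured; it differs from compound 3 by 2,3-diaminopropyl in place of 1,2-diaminoethyl on a saturated chain carbon, three bonds along the chain from an amide-type nitrogen. The difference between the core of compound 1 and the core of compound 3 is not broken down here. The change from compound 3 to compound 4 is the same kind of change as that from compound 1 to compound 2, but not the same: in the first pair the place is a saturated chain carbon bound to a carbonyl carbon, in the second a saturated chain carbon three bonds along the chain from an amide-type nitrogen. Going by the values given here, with only one earlier instance, the expectation leans on that one alone.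

For compound 4 the expected step is a number 3.2 percentage points higher from compound 3 to compound 4 (within the scatter), because a number 5.3 percentage points higher from compound 1 to compound 2 (within the scatter) stayed within the scatter. Compound 4 is therefore estimated at 44%, with a range from 32% to 56% that allows for the ordinary scatter of this assay.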

Compound 4, a percentage reported as activity, at one concentration (the size of the read-out at that concentration, not a potency): 41.2%
For compound 4 the middle estimate is 2.8 percentage points above the measured one; the range from low to high includes it.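

In this assay the lengthening of the diamine chain, 2,3-diaminopropyl in place of 1,2-diaminoethyl, gave a number 0.4 percentage points higher from compound 3 to compound 4 (within the scatter), and on the other core the same kind of change gave a number 5.3 percentage points higher from compound 1 to compound 2 (within the scatter). This shows that in both pairs the step stayed within the scatter, so the outcome carried over from one core to the other, at a saturated chain carbon bound to a carbonyl carbon in the first pair and at a saturated chain carbon three bonds along the chain from an amide-type nitrogen in the second; it does not show that the change is without any effect, since a small real step could lie hidden within the scatter, and two pairs cannot establish a rule for other cores in the series. Nothing available explains why the read-out responds to this change as it does.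

The compounds shown leave open whether a still longer diamine chain, a chain ending in a single amine, or a carboxylic acid in place of one of the amines would move the read-out beyond the scatter on either core. They also leave open what the difference between the two cores contributes on its own.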